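Quinoline to Methoxypyridine on a Thiourea Nitrogen

This account rests on a few compounds, and the source may have more. Where it says the series, first, only, none or still open, it means among the compounds named here.

Of the compounds shown here, two share one core and have been measured. In an assay on membranes from brain for binding affinity to Lysophosphatidylserine lipase ABHD12 (Mus musculus), read by fluorescence, with a stated time of 20 min, tested at 2 uM (a lower number here means a weaker effect, a higher number a stronger effect of the compound at the concentration tested), compound 1 `O=C(Nc1cccnc1)NC1CCN(c2ncc(C(F)(F)F)cc2Cl)CC1` gives 1%, while compound 2 `FC(F)(F)c1cnc(N2CCC(NC(=S)Nc3cnc4ccccc4c3)CC2)c(Cl)c1` gives 0%; these two numbers sit within the scatter of each other, so no order can be read from them. Compound 3 `COc1ccc(NC(=S)NC2CCN(c3ncc(C(F)(F)F)cc3Cl)CC2)cn1` differs from compound 2 in one place: 6-methoxypyridin-3-yl in place of quinolin-3-yl on an amide-type nitrogen. Within the data shown here, no measured pair shows what this change does. The step of a number 2 percentage points higher from compound 2 to compound 3 (within the scatter) is expected to be none beyond the scatter, because compound 2 gives 0% and nothing points elsewhere. Compound 3 is therefore estimated at 2%, within -8% to 12%.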

Compound 3, a percentage reported as inhibition, at one concentration (the size of the read-out at that concentration, not a potency): 0%
Estimate against measurement, compound 3: 2 percentage points above; measured number inside the range.
By their numbers in this assay, from the lowest: compounds 2, 3 and 1 (each within the scatter of the next).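

In this assay, 6-methoxypyridin-3-yl in place of quinolin-3-yl on this amide-type nitrogen gives no change at the digits printed from compound 2 to compound 3 (within the scatter) and so leaves the read-out unmoved. This first measured pair at the position shows that losing the carbon-only aromatic ring and gaining a methoxy group makes no visible difference at the concentration tested. No measurement here offers an explanation for this result.

With both compounds giving no measurable effect, the pair cannot show what this position tolerates or prefers. From the compounds shown here alone, whether a carboxylic acid, an amine or a longer alkyl chain on this nitrogen would give a real read-out remains open.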